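This account rests on a few compounds, and the source may have more. Where it says the series, first, only, none or still open, it means among the compounds named here.

Compound 2 `O=C(/C=C/c1c[nH]c2ccccc12)Nc1ccc2ncnc(Nc3cccc(Cl)c3)c2c1` gives 7020 nM in a functional assay on HepG2 cells (Homo sapiens) for antiproliferative activity, read by MTT assay, with a stated time of 48 h (a higher number here means a weaker inhibitor, a lower number a stronger inhibitor), and compound 1 `O=C(/C=C/c1ncc2ccccc2n1)Nc1ccc2ncnc(Nc3cccc(Cl)c3)c2c1` gives 7790 nM; the two sit within the scatter of each other, as a 1.1-fold lower number from compound 1 to compound 2 (0.05 log units; within the scatter) shows. Compound 3 `Cc1cccc(/C=C/C(=O)Nc2ccc3ncnc(Nc4cccc(Cl)c4)c3c2)n1` carries 6-methylpyridin-2-yl in place of 1H-indol-3-yl on a double-bonded chain carbon bound to a double-bonded chain carbon. For the measured compounds named here, the only step that bears on this position, a 1.1-fold lower number from compound 1 to compound 2 (0.05 log units; within the scatter), exchanged one aromatic group for another without moving the number beyond the scatter. On that basis the step of a 1.1-fold higher number from compound 2 to compound 3 (0.06 log units; within the scatter) is expected to stay within the scatter. Compound 3 is therefore estimated at 8000 nM in this assay, with a range from 3000 nM to 20000 nM.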

Compound 3, half-maximal inhibitory concentration: 4820 nM
Beside the measured number, compound 3's estimate is 1.7-fold (0.22 log units) above it; the measured number falls inside the stated range.
By their numbers in this assay, from the lowest: compounds 3, 2 and 1 (each within the scatter of the next).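

In this assay, a single aromatic ring at this place reads the same as the two larger groups, with a 1.5-fold lower number from compound 2 to compound 3 (0.16 log units; within the scatter) and a 1.6-fold lower number from compound 1 to compound 3 (0.21 log units; within the scatter). For the compounds shown here, replacing 1H-indol-3-yl with 6-methylpyridin-2-yl removes one ring and the hydrogen-bond donor and adds a hydrogen-bond acceptor, yet no step leaves the scatter, so none of these differences registers here. No evidence is available to explain this result.

All three compounds carry an aromatic group on the double-bonded chain carbon, so the compounds shown do not say whether the number would hold with a non-aromatic group there, such as an amine or a carboxylic acid. No group shown yet separates from the others beyond the scatter.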